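The source may report more compounds than this note shows. Statements on the series, on what has been measured and on what is new or still open speak of the compounds shown alone.

Working notes on the series. Compound 1 (`Cc1cc(Nc2cc(-c3ccccc3)[nH]n2)n2nc(SCC(=O)c3ccccc3)nc2n1`) gives 33300 nM in an ADME assay on GES1 cells (Homo sapiens) for inhibition, read by MTT assay, with a stated time of 72 h (a higher number here means a weaker inhibitor, a lower number a stronger inhibitor), and so sits level, within the scatter, with compound 3 (`Cc1cc(Nc2ccn(Cc3ccc(F)cc3)n2)n2nc(SCc3ccc(Br)cc3)nc2n1`) at 40500 nM in the same read-out. Compound 2 (`Cc1cc(Nc2cc(C(C)(C)C)[nH]n2)n2nc(SCc3ccc(Br)cc3)nc2n1`) reads > 50000 nM in this assay as a limit of the assay and not a number.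

Compound 4 (`Cc1ccc(CSc2nc3nc(C)cc(Nc4cc(-c5ccccc5)[nH]n4)n3n2)cc1`) departs from compound 1 on a saturated chain carbon bound to a sulfur, with 4-methylphenyl in place of benzoyl (4-methylphenyl in place of benzoyl on a saturated chain carbon bound to a sulfur). Cut one bond further out, this reads benzoylmethyl to 4-methylbenzyl. No two measured compounds differ in one place only, so the size of this change in this assay is not shown directly. The estimated step (a 1.1-fold higher number from compound 1 to compound 4 (0.02 log units; within the scatter)) is expected to stay within the scatter, in neither direction. This expectation rests on compound 1 at 33300 nM and on compound 3 at 40500 nM in the same range. A reading at the limit also stays possible, as with compound 2 (> 50000 nM). For compound 4 the estimated value is 35000 nM with an expected range from 15000 nM to 70000 nM in this assay.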

Compound 4, half-maximal inhibitory concentration: 36200 nM
Estimate against measurement, compound 4: 1.0-fold (0.01 log units) below, and the stated range covers the measured number.
By their numbers in this assay, from the lowest: compounds 1, 4 and 3 (each within the scatter of the next). At a limit, above all of these: compound 2.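

Among these compounds, the first one-place comparison shows that, in this assay, 4-methylphenyl in place of benzoyl on a saturated chain carbon bound to a sulfur gives a 1.1-fold higher number from compound 1 to compound 4 (0.04 log units; within the scatter). The carbonyl and its hydrogen-bond acceptor leave with benzoyl, and in this pair the number does not move beyond the scatter. This holds for this one change on the core of compound 1 and is no rule for the position as a whole.

Going by these compounds, whether an amine or a carboxylic acid carried on the same chain carbon would shift the number remains open. The read-out also ends in a limit, and compound 2 stands there as a limit of the assay and not a number: the limit of > 50000 nM in this assay, at which 1 of the 4 values shown sits.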